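Imidazole for Pyridine at the Chain End of Compound 2

The compounds below may be only part of what the source reports. "The series", "measured", "known", "first", "only" and "open" are said of these compounds alone.

Three acylguanidines were measured in a functional assay on Sf9 cells for antagonist activity at histamine H2 receptor (Homo sapiens), with stated times of 2 min and 20 min; on this read-out higher numbers stand for higher potency (the scale is a negative logarithm) and lower numbers for lower potency. Compound 1 `CC(CC(=O)/N=C(\N)NCCCc1ccccc1)c1ccccc1` gives 5.89. Compound 2 `N/C(=N\C(=O)CC(c1ccccc1)c1ccccc1)NCCCc1ccccn1` gives 5.68, and compound 3 `CC(CC(=O)/N=C(\N)NCCCc1ccc(CN(C)C)o1)c1cccs1` gives 6.51. Among these three numbers compound 2 has the lowest; its nearest neighbour is compound 1, whose number is within the usual scatter of it, while compound 3 lies beyond the scatter above it. Compound 4 `N/C(=N\C(=O)CC(c1ccccc1)c1ccccc1)NCCCc1ncc[nH]1` has not yet been measured in this assay. It differs from compound 2 in one place: 1H-imidazol-2-yl in place of pyridin-2-yl on a saturated chain carbon, three bonds along the chain from an amine nitrogen. Going by the values given here, no measured pair in this set shows exactly this exchange, so the size of the step can only be guessed. Since the two ring-for-ring variations already seen, compound 2 at 5.68 and compound 3 at 6.51, span a gap beyond the scatter, a change of the terminal ring can plausibly move the number, and the step from compound 2 to compound 4 is expected to be a number 0.62 log units higher from compound 2 to compound 4 (beyond the scatter), an increase. Compound 4 is therefore estimated at 6.3, with a range from 5.5 to 7.1.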

Compound 4, negative logarithm of the antagonist equilibrium constant: 6.13
Compound 4: the middle estimate sits 0.17 log units above what was measured; the range from low to high includes it.
By their numbers in this assay, from the lowest: compounds 2, 1 and 4 (each within the scatter of the next, the first and the last beyond it); then compound 3.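

In this assay, the exchange of pyridin-2-yl for 1H-imidazol-2-yl on a saturated chain carbon gives a number 0.45 log units higher from compound 2 to compound 4 (beyond the scatter), a modest step. Going by these compounds alone, the earlier compounds differ from each other in more than one place, so this pair is the first to tie a change in the number to the terminal ring alone. The exchange replaces a six-membered aromatic ring with a five-membered one and adds a hydrogen-bond donor, but nothing available shows which of these differences, if either, accounts for the step.

Going by these compounds, it remains open whether a thiazole ring, a primary amine or a longer chain at this position would raise the number further or lower it. Also unresolved is whether the same exchange would give a similar step on the core of compound 1.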